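Arylpiperazine Sulfonamides at the Adenosine A2b Receptor

The compounds below may be only part of what the source reports. "The series", "measured", "known", "first", "only" and "open" are said of these compounds alone.

Measured compounds:
compound 1 `CCCn1c(=O)[nH]c2nc(-c3ccc(S(=O)(=O)N4CCN(c5ccccc5Cl)CC4)cc3)[nH]c2c1=O` 0.403 nM
compound 2 `CCCn1c(=O)[nH]c2nc(-c3ccc(S(=O)(=O)N4CCN(c5ccc(F)cc5)CC4)cc3)[nH]c2c1=O` 0.644 nM
compound 3 `CCCn1c(=O)[nH]c2nc(-c3ccc(S(=O)(=O)N4CCN(c5cccc(Cl)c5)CC4)cc3)[nH]c2c1=O` 0.342 nM

In an assay on CHO cells for displacement of a labelled ligand from adenosine receptor A2b (Homo sapiens), read by scintillation counting, with a stated time of 75 min, in the presence of a further agent that is not named here (a lower number here means a stronger inhibitor, a higher number a weaker inhibitor), compound 3 gives the lowest of the three numbers, yet its gaps to its neighbours, a 1.2-fold lower number from compound 1 to compound 3 (0.07 log units; within the scatter) and a 1.9-fold lower number from compound 2 to compound 3 (0.27 log units; within the scatter), both lie within the scatter, as does a 1.6-fold higher number from compound 1 to compound 2 (0.20 log units; within the scatter). Compound 4 `CCCn1c(=O)[nH]c2nc(-c3ccc(S(=O)(=O)N4CCN(Cc5cccc(Br)c5)CC4)cc3)[nH]c2c1=O` differs from compound 3 by 3-bromobenzyl in place of 3-chlorophenyl on an amine nitrogen in a ring. For the measured compounds named here, no measured step matches this change: the three steps seen swap only the substituent on a phenyl that sits directly on the amine nitrogen, and none moved the number beyond the scatter. Going by the values given here, with no step of this kind to lean on, compound 4 is expected to stay close to compound 3, the estimated step being a 1.8-fold higher number from compound 3 to compound 4 (0.24 log units; within the scatter). Compound 4 is therefore estimated at 0.6 nM, within 0.15 nM to 2.5 nM.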

Compound 4, inhibition constant: 0.148 nM
Compound 4: middle estimate off by 4.1-fold (0.61 log units), on the high side; the measured number lies below the stated range.
By their numbers in this assay, from the lowest: compound 4; then compounds 3, 1 and 2 (each within the scatter of the next).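

In this assay, for the compounds shown here, the 3-bromobenzyl group gives the first steps beyond the scatter at this amine nitrogen in a ring: a 2.3-fold lower number from compound 3 to compound 4 (0.36 log units; beyond the scatter) and a 2.7-fold lower number from compound 1 to compound 4 (0.44 log units; beyond the scatter) and a 4.4-fold lower number from compound 2 to compound 4 (0.64 log units; beyond the scatter). All three steps are modest, yet they show that this position responds to a change, whereas swaps among the phenyl groups of compound 1, compound 2 and compound 3 stayed within the scatter. Nothing shown here explains these steps.

The change adds a carbon and exchanges chlorine for bromine at once, so the two remain unseparated. A 3-chlorobenzyl or 3-bromophenyl group could separate them, and a longer chain such as 3-bromophenethyl would test the reach of this position.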